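The source may report more compounds than this note shows. Statements on the series, on what has been measured and on what is new or still open speak of the compounds shown alone.

Measured compounds:
compound 1 `Nc1ncnc2c1c(C(=O)c1cccc(NS(=O)(=O)c3c(F)cccc3F)c1)cn2C1CCCC1` — "not determined" (no result reported) in an ADME assay on microsomes from liver (Rattus norvegicus) for metabolic stability; a higher number here means that the liver removes a larger share of the compound in one pass, a lower number that the liver removes a smaller share
compound 2 `Nc1ncnc2c1c(C(=O)c1cccc(NC(=O)Nc3ccc(Cl)cc3Cl)c1)cn2C1CCCC1` — "not determined" (no result reported) in this assay
compound 3 `Cc1ccc(F)c(NC(=O)Nc2cccc(C(=O)c3cn(C4CCCC4)c4ncnc(N)c34)c2)c1` — 0.8 in this assay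

Compound 1 `Nc1ncnc2c1c(C(=O)c1cccc(NS(=O)(=O)c3c(F)cccc3F)c1)cn2C1CCCC1` shares the core with compound 3 but carries no reported number in this assay, where compound 1 is recorded as "not determined" (no result reported). Compound 2 `Nc1ncnc2c1c(C(=O)c1cccc(NC(=O)Nc3ccc(Cl)cc3Cl)c1)cn2C1CCCC1` shares the same core and also carries no reported number, as compound 2 is recorded as "not determined" (no result reported). Compound 3 therefore stands alone, and its value of 0.8 in this assay shows that the liver removes most of it in one pass. Compound 4 `COc1ccc(C)cc1NC(=O)Nc1cccc(C(=O)c2cn(C3CCCC3)c3ncnc(N)c23)c1` differs from compound 3 in one place: methoxy in place of fluoro on an aromatic carbon. Because compound 3 gives 0.8, compound 4 is expected to stay high, with a step no larger than the scatter, if anything slightly upward: a number 0.050 higher from compound 3 to compound 4 (within the scatter). The estimate for compound 4 in this assay is 0.85, expected to fall between 0.65 and 0.95.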

Compound 4, hepatic extraction ratio: 0.69
Compound 4: middle estimate off by 0.16, on the high side, and the stated range covers the measured number.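

In this assay, placing methoxy instead of fluoro on this aromatic carbon, ortho to a large group and para to a methyl group, gives a number 0.11 lower from compound 3 to compound 4 (beyond the scatter). The position therefore affects the read-out, although compound 4, at 0.69, is still removed in large part by the liver. No measurement shown bears on the reason for this step. The compounds shown leave open whether an amine or a hydroxyl group on this carbon would lower the number further, and whether an ethoxy group would extend the step.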